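This account rests on a few compounds, and the source may have more. Where it says the series, first, only, none or still open, it means among the compounds named here.

Measured in a functional assay on ASPC1 cells (Homo sapiens) for inhibition, read by MTT assay, with a stated time of 96 h; on this read-out higher numbers stand for weaker inhibition of growth and lower numbers for stronger inhibition of growth:
- compound 1 `CC(C)C(=O)SCCCCCCNC(=O)c1cc(-c2ccncc2)n[nH]1`: 31700 nM
- compound 2 `CCCC(=O)SCCCCCCNC(=O)c1cc(-c2ccncc2)n[nH]1`: 28100 nM

Compound 2, at 28100 nM, cannot be told apart from compound 1, because a 1.1-fold lower number from compound 1 to compound 2 (0.05 log units; within the scatter). Compound 3 `CSCCCCCCNC(=O)c1cc(-c2ccncc2)n[nH]1` has not yet been measured. Its difference from compound 2 is methyl in place of propylcarbonyl on a sulfur.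

Going by the values given here, only one measured step bears on this change, and only loosely. It swapped isopropyl for propyl on a carbonyl carbon and kept the carbonyl, whereas this change removes it. Among the compounds with values here, no measured compound shows what that removal does. With so little evidence, no step beyond the scatter is expected in this assay, with a slight lean towards a higher number, meaning weaker inhibition of growth. The estimated step is a 1.4-fold higher number from compound 2 to compound 3 (0.15 log units; within the scatter). The expected value for compound 3 is 40000 nM, with an estimated range of 15000 nM to 100000 nM.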

Compound 3, concentration for 50% growth inhibition: > 50000 nM
Compound 3: a limit, no number (the forecaster's own chance of this, stated with the estimate: 25%); middle value at least 1.2-fold (0.09 log units) away from the limit.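

In this assay compound 3 gives > 50000 nM, which is a limit of the assay and not a number. Replacing the acyl group on the sulfur with methyl, which removes the carbonyl rather than only reshaping the carbon group on it, gives an at least 1.7-fold higher number from compound 2 to compound 3 (0.25 log units; that floor lies within the scatter) and also an at least 1.5-fold higher number from compound 1 to compound 3 (0.19 log units; that floor lies within the scatter), so this change brings no stronger inhibition of growth. How large these steps really are stays unknown, since compound 3 sits at the limit: the limit of > 50000 nM in this assay, at which 1 of the 3 values shown sits.

The compounds shown leave open whether the carbonyl itself counts or the rest of the group on the sulfur. They give no reading for an acetyl group or a free thiol on that sulfur, or for a shorter or longer chain.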